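Swapping bromo for methyl on the aryl ring

The source may hold more compounds than are shown below. What is called first, only, known or untested is meant among the compounds shown, and "the series" means these compounds.

Compound 1 (`C#CCSc1nc(Sc2nccs2)c(C#N)c(-c2ccc(Br)cc2)n1`) gives 3990 nM
Compound 2 (`C#CCSc1nc(Sc2nncs2)c(C#N)c(-c2cc(OC)c(OC)c(OC)c2)n1`) gives 4660 nM

In a functional assay on SMMC-7721 cells (Homo sapiens) for antiproliferative activity, read by MTT assay, with a stated time of 72 h (on this read-out higher numbers stand for weaker inhibition and lower numbers for stronger inhibition), compound 1 gives 3990 nM and compound 2 gives 4660 nM, so these two values lie within the usual scatter of each other. Compound 3 (`C#CCSc1nc(Sc2nccs2)c(C#N)c(-c2ccc(C)cc2)n1`) keeps the core of compound 1 and changes in one place only: methyl in place of bromo on an aromatic carbon. This puts methyl in place of bromo on an aromatic carbon, turning 4-bromophenyl into 4-methylphenyl. Among the measured compounds shown here, no two measured compounds differ in just one place, so the data offer no direct guide to this swap. The expectation therefore starts from compound 1 at 3990 nM and allows for a small drift toward a higher number, probably not beyond the scatter. The expected change is a 1.4-fold higher number from compound 1 to compound 3 (0.14 log units; within the scatter). For compound 3 the estimated value is 5500 nM, with an expected range from 2000 nM to 15000 nM.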

Compound 3, half-maximal inhibitory concentration: 2450 nM
For compound 3 the middle estimate is 2.2-fold (0.35 log units) above the measured one; low and high end bracket the measured number.
By their numbers in this assay, from the lowest: compounds 3, 1 and 2 (each within the scatter of the next).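

Among the compounds shown here, this is the first pair here that differs in one place only, so it gives the first direct reading of this position. In this assay the swap of bromo for methyl on the aromatic carbon gives a single step (a 1.6-fold lower number from compound 1 to compound 3 (0.21 log units; within the scatter)). The numbers therefore do not separate 4-bromophenyl from 4-methylphenyl, and nothing measured here explains the result or bears on it further.

From the compounds shown here alone, both groups are single heavy atoms, so it remains open whether a larger or very different group at this position, such as an amine, a carboxylic acid or a longer alkyl chain, would move the number beyond the scatter. Compound 2 differs from these compounds in more than one place, so it cannot settle that question.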